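The source may hold more compounds than are shown below. What is called first, only, known or untested is meant among the compounds shown, and "the series" means these compounds.

The measured compounds in this series are:

Compound 1, `CC(C)(C)c1ccc(NC(=O)c2ccc(-c3ncccc3C#N)cc2)cc1`, giving 30 nM in a functional assay for antagonist activity at transient receptor potential cation channel subfamily V member 1 (Homo sapiens), read by FLIPR; a higher number here means a weaker inhibitor, a lower number a stronger inhibitor.
Compound 2, `CC(C)(C)c1ccc(NC(=O)c2ccc(-c3ncccc3NS(C)(=O)=O)cc2)cc1`, giving 152 nM in this assay.
Compound 3, `CC(C)(C)c1ccc(NC(=O)c2ccc(-c3ncccc3NS(=O)(=O)c3ccccc3)cc2)cc1`, giving 91 nM in this assay.

Compound 3 has the second highest of the three numbers. Its nearest neighbour is compound 2, and the change was a 1.7-fold lower number from compound 2 to compound 3 (0.22 log units; within the scatter), which does not exceed the scatter. Its furthest neighbour is compound 1, and the change was a 3.0-fold higher number from compound 1 to compound 3 (0.48 log units; beyond the scatter).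

Compound 4, `CC(C)(C)c1ccc(NC(=O)c2ccc(-c3ncccc3-c3ncc[nH]3)cc2)cc1`, differs from compound 3 in one place: 1H-imidazol-2-yl in place of (phenylsulfonyl)amino on an aromatic carbon. Within the data shown here, no measured step covers an imidazolyl group, so the expectation rests on what the cyano and sulfonamide variants show. The two steps that bear on it are a 5.1-fold higher number from compound 1 to compound 2 (0.70 log units; beyond the scatter) and a 3.0-fold higher number from compound 1 to compound 3 (0.48 log units; beyond the scatter), both modest and both in the direction of a higher number when the cyano group was replaced. A third step, a 1.7-fold lower number from compound 2 to compound 3 (0.22 log units; within the scatter), shows that exchanging one sulfonyl substituent for another changed little. The imidazolyl group is closer in size to the cyano group than the sulfonamides are, so compound 4 is expected to land somewhere between compound 1 and compound 3, with the step of a 1.5-fold lower number from compound 3 to compound 4 (0.18 log units; within the scatter) estimated to stay within the scatter. Compound 4 is therefore estimated at 60 nM, with a range from 20 nM to 200 nM.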

Compound 4, half-maximal inhibitory concentration: 3670 nM
Estimate against measurement, compound 4: 61-fold (1.79 log units) below; measured number outside the range, above it.
By their numbers in this assay, from the lowest: compound 1; then compounds 3 and 2 (each within the scatter of the next); then compound 4.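

At this place on the ring, ortho to a large group and two atoms from the ring nitrogen, the earlier replacements of cyano had given only modest steps in this assay, a 5.1-fold higher number from compound 1 to compound 2 (0.70 log units; beyond the scatter) and a 3.0-fold higher number from compound 1 to compound 3 (0.48 log units; beyond the scatter), whereas 1H-imidazol-2-yl gives a 120-fold higher number from compound 1 to compound 4 (2.09 log units; beyond the scatter) and so marks this position as far less tolerant of some groups than the sulfonamides had suggested. The two sulfonamides lie within the scatter of each other, and both stand well clear of the new compound, with a 24-fold higher number from compound 2 to compound 4 (1.38 log units; beyond the scatter) and a 40-fold higher number from compound 3 to compound 4 (1.61 log units; beyond the scatter), so the number here does not follow group size alone: 1H-imidazol-2-yl has fewer heavy atoms than (phenylsulfonyl)amino, yet it gives the higher number. Nothing at hand accounts for this jump.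

From the compounds shown here alone, how a thiazol-2-yl or a 1-methylimidazol-2-yl group would fare at this place stays open, and with it whether the high number belongs to the 1H-imidazol-2-yl group itself or to five-membered aromatic rings more widely. Where an amine or a carboxylic acid would fall on the same scale is equally open.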